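The source may report more compounds than this note shows. Statements on the series, on what has been measured and on what is new or still open speak of the compounds shown alone.

In an ADME assay on MCF7 cells (Homo sapiens) for cytotoxicity, with a stated time of 72 h (on this read-out lower numbers stand for stronger inhibition and higher numbers for weaker inhibition), compound 1 (`COc1ccc(CNc2ncnc3c2ncn3C2CCCCO2)c(OC)c1OC`) reads > 37500 nM as a limit, not a number. Compound 2 (`COc1ccc(CNc2ncnc3c2ncn3C2CCCO2)cc1OC`) reads > 100000 nM as a limit too. Compound 3 (`COc1ccc(CNc2ncnc3c2ncn3C2CCCO2)c(OC)c1`) also reads > 100000 nM as a limit, so it has no exact number. That places compound 3 at the limit of > 100000 nM in this assay, at which 2 of the 3 values shown sit, and not at the limit of > 37500 nM in this assay, at which 1 of the 3 values shown sits, in the set. Compound 4 (`COc1ccc(CNc2ncnc3c2ncn3C2CCCO2)c(OC)c1OC`) has methoxy in place of hydrogen on an aromatic carbon, ortho to two methoxy groups (methoxy in place of hydrogen on an aromatic carbon). Going by the values given here, no measured pair shows this change alone, and limits give no size of step to build on, so no change beyond the scatter is expected in this assay here. The expected step of a number no higher from compound 3 to compound 4 (the limit leaves the size open) is accordingly no real shift. The expected value for compound 4 is 100000 nM within an estimated range of 30000 nM to 200000 nM and it may well turn out to be only a limit.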

Compound 4, half-maximal inhibitory concentration: > 100000 nM
Compound 4 ended at the assay's limit; the forecaster's own chance of this, stated with the estimate: 85%; the middle value sits exactly at the limit.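

Going by these compounds alone, compound 4, like compound 1, compound 2 and compound 3, gives only a limit and not a number, so no step among them can be read. On these data alone, whether methoxy in place of hydrogen, or oxolan-2-yl in place of oxan-2-yl, changes the read-out at all stays open.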